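This account rests on a few compounds, and the source may have more. Where it says the series, first, only, none or still open, it means among the compounds named here.

In an ADME assay on microsomes (Homo sapiens) for metabolic stability (on this read-out lower numbers stand for a shorter-lived compound and higher numbers for a longer-lived compound), compound 1 `O=C(c1cn[nH]c1)N1CCC(C(=O)N2N=CCC2c2ccccc2)CC1` gives > 2.75 h, which is a limit of the assay and not a number. Compound 1 therefore stands at the limit of > 2.75 h in this assay, at which 1 of the 2 values shown sits. Compound 2 `N#Cc1nccc(N2CCC(C(=O)N3N=CC[C@H]3c3cc(F)cc(F)c3)CC2)n1` gives a true number in this assay, 2.1 h.

Compound 3 `O=C(c1cocn1)N1CCC(C(=O)N2N=CCC2c2ccccc2)CC1` keeps the core of compound 1 and changes one group: 1,3-oxazol-4-yl in place of 1H-pyrazol-4-yl on a carbonyl carbon. In words, 1,3-oxazol-4-yl takes the place of 1H-pyrazol-4-yl on a carbonyl carbon, so one five-membered aromatic ring replaces another.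

Among the compounds with values here, no measured pair here shows what this swap does, so the expectation is cautious: no change beyond the usual scatter, in either direction. The only anchor for that expectation is compound 1 at > 2.75 h, and that anchor is a limit. The estimated change is small, a step that the limit leaves unreadable from compound 1 to compound 3. The assay may well report only a limit again. The estimated value for compound 3 in this assay is 3 h, with an expected range of 1.5 h to 6 h.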

Compound 3, half-life: > 2.75 h
Compound 3: no number, only a limit; the forecaster's own chance of this, stated with the estimate: 50%; the middle value does not contradict the limit.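

In this assay compound 3 gives > 2.75 h as a limit of the assay and not a number. Within the data shown here, compound 1 also stands at a limit, so no step between compound 1 and compound 3 can be read: the limit of > 2.75 h in this assay, at which 2 of the 3 values shown sit.

The compounds shown leave open whether 1,3-oxazol-4-yl in place of 1H-pyrazol-4-yl changes the half-life at all.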